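A few compounds are considered here, and "the series" means these few. Any claim that something is new, unique, unknown or untested is made for them only; others in the source may bear on it.

Measured compounds:
- Compound 1 `O=C(Nc1ccc(NC2CCCCC2)cc1Cl)c1cc(Cl)ccc1O`: 68300 nM
- Compound 2 `CN(C)c1ccc(NC(=O)c2cc(Cl)ccc2O)c(Cl)c1`: 85100 nM
- Compound 3 `CCCN(CCC)c1ccc(NC(=O)c2cc(Cl)ccc2O)c(Cl)c1`: 10700 nM

In an ADME assay on A549 cells (Homo sapiens) for cytotoxicity, read by resazurin assay, with a stated time of 48 h (on this read-out higher numbers stand for lower toxicity in this test and lower numbers for higher toxicity in this test), compound 1 gives 68300 nM, the second highest of the three numbers. Compound 2 sits nearest to it, with a 1.2-fold higher number from compound 1 to compound 2 (0.10 log units; within the scatter), while compound 3 stands furthest away, with a 6.4-fold lower number from compound 1 to compound 3 (0.81 log units; beyond the scatter); compound 2 and compound 3 are separated by an 8.0-fold lower number from compound 2 to compound 3 (0.90 log units; beyond the scatter).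

Compound 4 `O=C(Nc1ccc(NCc2cc(F)cc(Cl)c2)cc1Cl)c1cc(Cl)ccc1O` has not yet been measured. It differs from compound 1 in one place: 3-chloro-5-fluorobenzyl in place of cyclohexyl on a nitrogen on an aromatic ring.

The two steps already seen at this nitrogen bear on the change. Both replace the cyclohexyl group, and they range from no movement beyond the scatter to a modest drop in the number. Among the compounds with values here, no measured step puts a benzyl group on this nitrogen, so the direction is not fixed by direct precedent. On balance a modest lowering is expected for compound 4, of about a 2.3-fold lower number from compound 1 to compound 4 (0.36 log units; beyond the scatter). The estimate for compound 4 is 30000 nM, within a range from 10000 nM to 90000 nM.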

Compound 4, half-maximal cytotoxic concentration: 11100 nM
For compound 4 the middle estimate is 2.7-fold (0.43 log units) above the measured one; measured number inside the range.
By their numbers in this assay, from the lowest: compounds 3 and 4 (each within the scatter of the next); then compounds 1 and 2 (each within the scatter of the next).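

In this assay, 3-chloro-5-fluorobenzyl in place of cyclohexyl on a nitrogen on an aromatic ring gives a 6.2-fold lower number from compound 1 to compound 4 (0.79 log units; beyond the scatter), which means higher toxicity in this test. Until now, only dipropylamino had moved the number beyond the scatter; this result shows that a group with a six-membered aromatic ring can do so too, with compound 3 at 10700 nM and compound 4 at 11100 nM lying within the scatter of each other. Nothing measured here accounts for this drop.

From the compounds shown here alone, whether the drop comes from the benzyl group itself or from its chlorine and fluorine remains open, a question that an unsubstituted benzyl group would address. How a phenyl group or a hydroxyethyl chain on this nitrogen would read in this assay is also unknown.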